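Branched Phenylalkyl Replaces Benzyl on the Aromatic Nitrogen

The source may report more compounds than this note shows. Statements on the series, on what has been measured and on what is new or still open speak of the compounds shown alone.

In an assay on Prostate gland for inhibition of steroid 5-alpha-reductase (Rattus norvegicus) (a higher number here means a weaker inhibitor, a lower number a stronger inhibitor), three compounds have been measured:
compound 1 `CCCCC(CC)n1ccc2cc(/C(C)=C/C(=O)Nc3ccccc3OCCCC(=O)O)ccc21` gives 7.1 nM
compound 2 `CCCCCC(CCCCC)n1ccc2cc(/C(C)=C/C(=O)Nc3ccccc3OCCCC(=O)O)ccc21` gives 25 nM
compound 3 `C/C(=C\C(=O)Nc1ccccc1OCCCC(=O)O)c1ccc2c(ccn2Cc2cccc(C)c2)c1` gives 250 nM

Compound 3 carries the highest number of the three. Both steps into it, a 35-fold higher number from compound 1 to compound 3 (1.55 log units; beyond the scatter) and a 10-fold higher number from compound 2 to compound 3 (1.00 log units; beyond the scatter), run upward, the first large, the second modest; between the two branched alkyl compounds the step of a 3.5-fold higher number from compound 1 to compound 2 (0.55 log units; beyond the scatter) is the smallest seen. Compound 4 `CCCCCC(c1ccccc1)n1ccc2cc(/C(C)=C/C(=O)Nc3ccccc3OCCCC(=O)O)ccc21` is reached by 1-phenylhexyl in place of 3-methylbenzyl on an aromatic nitrogen. The entering group keeps a phenyl ring yet, like the groups of compound 1 and compound 2, is branched at the atom joined to the aromatic nitrogen. Because the steps of a 35-fold higher number from compound 1 to compound 3 (1.55 log units; beyond the scatter) and a 10-fold higher number from compound 2 to compound 3 (1.00 log units; beyond the scatter) both favour such branched groups, a lower number is expected in this assay. Compound 4 is estimated at 20 nM with a range from 6 nM to 70 nM. This expected step is a 13-fold lower number from compound 3 to compound 4 (1.10 log units; beyond the scatter).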

Compound 4, half-maximal inhibitory concentration: 25 nM
Compound 4: middle estimate off by 1.3-fold (0.10 log units), on the low side; the measured number falls inside the stated range.
By their numbers in this assay, from the lowest: compound 1; then compounds 2 and 4 (each within the scatter of the next); then compound 3.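

The step of a 10-fold lower number from compound 3 to compound 4 (1.00 log units; beyond the scatter) in this assay shows that a phenyl ring on the aromatic nitrogen is compatible with a much lower number when it sits within the branched 1-phenylhexyl group. Phenyl in place of pentyl on the branching carbon gives no change at the digits printed from compound 2 to compound 4 (within the scatter) and thus leaves the number unmoved, yet 1-ethylpentyl keeps its edge, with a 3.5-fold higher number from compound 1 to compound 4 (0.55 log units; beyond the scatter) as the step to the phenyl group. Nothing available explains these steps. As far as these compounds go, whether a shorter 1-phenylethyl group, or an amine on the phenyl ring of 1-phenylhexyl, would hold this number remains open.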